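Replacing the substituted phenyl amide group in compound 2

A few compounds are considered here, and "the series" means these few. Any claim that something is new, unique, unknown or untested is made for them only; others in the source may bear on it.

Compound 1 `Cc1cccc(NC(=O)C2(C(=O)Nc3ccc(Nc4ncc5cc(C(=O)N(C)C)n(C6CCCC6)c5n4)cc3)CC2)c1`: 95.3%
Compound 2 `CN(C)C(=O)c1cc2cnc(Nc3ccc(NC(=O)C4(C(=O)Nc5ccc(Cl)c(C(F)(F)F)c5)CC4)cc3)nc2n1C1CCCC1`: 55.8%
Compound 3 `Cc1ccc(NC(=O)C2(C(=O)Nc3ccc(Nc4ncc5cc(C(=O)N(C)C)n(C6CCCC6)c5n4)cc3)CC2)cc1`: not yet measured

In a functional assay on T47D cells (Homo sapiens) for inhibition, read by CCK-8 assay, with a stated time of 72 h, tested at 10 uM (a higher number here means more inhibition of growth at the concentration tested, a lower number less inhibition of growth), compound 2 gives 55.8%, the lower of the two numbers. Compound 1 gives 95.3%. The gap between these two numbers lies well beyond the scatter. The change now followed is 4-methylphenyl in place of 4-chloro-3-(trifluoromethyl)phenyl on an amide-type nitrogen.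

Within the data shown here, only one measured step bears on this change. It is a number 39.5 percentage points lower from compound 1 to compound 2 (beyond the scatter), a large step that put 4-chloro-3-(trifluoromethyl)phenyl in place of 3-methylphenyl at the same place. Among the measured compounds shown here, compound 3 removes that same group but carries 4-methylphenyl rather than 3-methylphenyl, and no measured pair compares these two groups directly. Much of the lost inhibition is therefore expected to return, though perhaps not all of it. The expected change in this assay is a large rise, a number 29.2 percentage points higher from compound 2 to compound 3 (beyond the scatter). The estimate for compound 3 is 85%, with an expected range from 62% to 100%.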

Compound 3, percent growth inhibition at one concentration: 99.6%
The estimate for compound 3 lay 14.6 percentage points below the measured number; measured number inside the range.
By their numbers in this assay, from the lowest: compound 2; then compounds 1 and 3 (each within the scatter of the next).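

In this assay the step of a number 43.8 percentage points higher from compound 2 to compound 3 (beyond the scatter) shows that the gap tied to 4-chloro-3-(trifluoromethyl)phenyl at this amide-type nitrogen is not peculiar to the comparison with 3-methylphenyl, since it appears again against a second methylphenyl group. The step of a number 4.3 percentage points higher from compound 1 to compound 3 (within the scatter) adds that this assay does not separate 4-methylphenyl from 3-methylphenyl at this place, so the two methylphenyl groups cannot be ranked, and the large difference lies between them and 4-chloro-3-(trifluoromethyl)phenyl. Nothing measured here accounts for why the groups differ in this way.

Chlorine and trifluoromethyl occur only together in the compounds shown, so it remains open whether either alone goes with the lower number, and a phenyl carrying only chlorine or only trifluoromethyl would separate the two. Also open, on these data alone, is where an unsubstituted phenyl or a methoxy-bearing phenyl would fall at this nitrogen, and whether compound 1 and compound 3 would still be indistinguishable at a lower concentration than the single one tested.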